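A few compounds are considered here, and "the series" means these few. Any claim that something is new, unique, unknown or untested is made for them only; others in the source may bear on it.

Measured compounds in an assay on HEK293 cells for displacement of a labelled ligand from Neuronal acetylcholine receptor; alpha4/beta2 (Homo sapiens), read by scintillation counting, with a stated time of 120 min; a higher number here means a weaker inhibitor, a lower number a stronger inhibitor:
compound 1 `c1ccc(COc2cccc(-c3cn(C4CN5CCC4CC5)nn3)c2)cc1` — 668 nM
compound 2 `c1ccc(COc2cccc(-c3cn([C@H]4CN5CCC4CC5)nn3)c2)cc1` — 5060 nM

Compound 1 gives the lower of the two numbers in this assay; the nearest measured neighbour is compound 2, and the step of a 7.6-fold higher number from compound 1 to compound 2 (0.88 log units; beyond the scatter) is a stereochemical one. The only observation bearing on it is the fact that one of compounds 1 and 2 is drawn with a defined configuration and the other without, at the place where they differ; it says nothing about the ether substituent.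

Compound 3 `FCCCOc1cccc(-c2cn(C3CN4CCC3CC4)nn2)c1` keeps the stereochemical drawing of compound 1 and changes only the ether: 2-fluoroethyl in place of phenyl on a saturated chain carbon bound to an oxygen on an aromatic ring. No measured pair shows this kind of exchange, so the step to compound 3 cannot be anchored on a shown number in this assay; the stereo step from compound 1 to compound 2 does not transfer to it. With the aryl ether shortened to a small fluorinated chain, a change in either direction of moderate size is plausible, and the expectation is kept close to compound 1 with a wide range.

For compound 3 the expected value in this assay is 1000 nM (range 200 nM to 5000 nM), that is an expected step of a 1.5-fold higher number from compound 1 to compound 3 (0.18 log units; within the scatter).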

Compound 3, inhibition constant: 3890 nM
Compound 3: the middle estimate sits 3.9-fold (0.59 log units) below what was measured; the range from low to high includes it.
By their numbers in this assay, from the lowest: compound 1; then compounds 3 and 2 (each within the scatter of the next).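

In this assay, the exchange of phenyl for 2-fluoroethyl on a saturated chain carbon bound to an oxygen on an aromatic ring gives a 5.8-fold higher number from compound 1 to compound 3 (0.77 log units; beyond the scatter). For the compounds shown here, this is the first measured change at the ether, and it shows that this place, and not only the stereo drawing of the core, moves the number, with the benzyl group favoured over 3-fluoropropyl in this pair. No observation at hand bears on the reason for this step.

The exchange removes the aromatic ring and brings in fluorine in one move, so a plain propyl or a 4-fluorobenzyl group would be needed to tell those two parts apart. Going by these compounds, whether a longer chain or a hydroxyl-ended chain at this place behaves like 3-fluoropropyl also stays open.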